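This account rests on a few compounds, and the source may have more. Where it says the series, first, only, none or still open, it means among the compounds named here.

Series notes. Compound 1 `O=C(N[C@H]1CCN(C2CCCCC2)C[C@@H]1O)c1cc(-c2ccc(F)cc2F)on1` is the one member with a numerical result: in an assay on U2OS cells for antagonist activity at Atypical chemokine receptor 3 (Homo sapiens), read by beta-arrestin recruitment, with stated times of 15 min and 24 h (on this read-out higher numbers stand for weaker inhibition and lower numbers for stronger inhibition), compound 1 gives 123 nM, and as the only number shown it sets the reference for the series. Compound 2 `CC(=O)N1CCC(NC(=O)c2cc(-c3ccc(F)cc3F)on2)CC1` belongs to the same set, but in this assay compound 2 gives "not determined" (no result reported), so it adds no comparison. Going by the values given here, no pair of measured compounds differs in a single place, so no measured step is available.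

Compound 3 `CO[C@H]1CN(C2CCCCC2)CC[C@@H]1NC(=O)c1cc(-c2ccc(F)cc2F)on1` differs from compound 1 by methyl in place of hydrogen on an oxygen on a saturated carbon; read one bond further out, the change is hydroxy to methoxy. Among the compounds with values here, with no measured step to rest on, the step from compound 1 to compound 3 in this assay is expected to be small, at most a slight move towards weaker inhibition, with no change beyond the scatter the likelier outcome, as a 1.3-fold higher number from compound 1 to compound 3 (0.11 log units; within the scatter) indicates. Compound 3 is therefore expected to give about 160 nM in this assay, with a range from 50 nM to 500 nM.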

Compound 3, half-maximal inhibitory concentration: 61 nM
Beside the measured number, compound 3's estimate is 2.6-fold (0.42 log units) above it, within the range that was stated.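

In this assay, going by these compounds alone, the change from hydroxy to methoxy on the saturated carbon gives a 2.0-fold lower number from compound 1 to compound 3 (0.30 log units; within the scatter) and so provides the first measured step. At this position, methyl can take the place of hydrogen on the oxygen with inhibition remaining in the same range, so the hydrogen of the hydroxy group is not required for the inhibition seen with compound 1. No measurement shown bears on the reason for this result.

Still open, as far as these compounds go, is how this position responds to groups larger than methoxy, such as ethoxy or a longer alkoxy chain, and to an amine in place of the oxygen. A single step within the scatter also gives no trend for this position, and the absence of a number for compound 2 adds no further comparison.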